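Trifluoromethyl in Place of Fluoro: Estimating Compound 4

The source may report more compounds than this note shows. Statements on the series, on what has been measured and on what is new or still open speak of the compounds shown alone.

Four compounds share one core and differ only in the aryl group on the amide-type nitrogen. In a functional assay on HeLa cells (Homo sapiens) for antiproliferative activity, read by sulforhodamine B assay, with a stated time of 72 h (on this read-out higher numbers stand for weaker inhibition and lower numbers for stronger inhibition), compound 1 `FC(F)(F)c1ccccc1NC(=S)N/N=C/c1ccc2ccccc2n1` gives 18800 nM. Compound 2 `Fc1ccccc1NC(=S)N/N=C/c1ccc2ccccc2n1` reaches only the limit of this assay, reported as > 100000 nM. Compound 3 `Fc1ccc(NC(=S)N/N=C/c2ccc3ccccc3n2)cc1` gives 33200 nM in this assay. The step of an at least 5.3-fold lower number from compound 2 to compound 1 (0.72 log units; beyond the scatter) follows the change (trifluoromethyl in place of fluoro on an aromatic carbon), and the step of an at least 3.0-fold lower number from compound 2 to compound 3 (0.47 log units; beyond the scatter) follows the change (4-fluorophenyl in place of 2-fluorophenyl on an amide-type nitrogen), where the two cores hold the same atoms joined differently. Both steps start from the limit described as the limit of > 100000 nM in this assay, at which 1 of the 3 values shown sits, so each is open at one end. Compound 4 `FC(F)(F)c1ccc(NC(=S)N/N=C/c2ccc3ccccc3n2)cc1` is not yet measured. It differs from compound 3 by trifluoromethyl in place of fluoro on an aromatic carbon, the same kind of change as that from compound 2 to compound 1, but here the group sits para to a large group rather than ortho to a large group. Because the earlier step of an at least 5.3-fold lower number from compound 2 to compound 1 (0.72 log units; beyond the scatter) begins at a limit, the expected step of a 2.2-fold lower number from compound 3 to compound 4 (0.35 log units; beyond the scatter) is taken as smaller and less certain. Compound 4 is therefore estimated at 15000 nM, expected to fall between 5000 nM and 45000 nM.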

Compound 4, half-maximal inhibitory concentration: 59100 nM
For compound 4 the middle estimate is 3.9-fold (0.60 log units) below the measured one; measured number outside the range, above it.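

In this assay, placing trifluoromethyl where fluoro stood on the core of compound 3 gives a 1.8-fold higher number from compound 3 to compound 4 (0.25 log units; within the scatter), so this step does not repeat the clear gain seen on the core of compound 1. Set side by side, the two results show that the effect of this change did not carry over from one core to the other in this series: the same change on two cores in this assay, an at least 5.3-fold lower number (0.72 log units; beyond the scatter) from compound 2 to compound 1 and a 1.8-fold higher number (0.25 log units; within the scatter) from compound 3 to compound 4, at least 9.4-fold (0.97 log units) apart, beyond the scatter of two such steps. Compound 2 stands at > 100000 nM, which is a limit and not a number, so the earlier step is open at one end, and two pairs of compounds cannot show why the change behaves differently on the two cores.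

The compounds shown leave open how other groups in the same place would behave on either core, such as chloro, methyl, methoxy, a nitrile or an amine. They also leave open whether any of these would follow the pair of compound 2 and compound 1 or the pair of compound 3 and compound 4.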